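A few compounds are considered here, and "the series" means these few. Any claim that something is new, unique, unknown or untested is made for them only; others in the source may bear on it.

Compound 1 `C=CC(=O)Nc1cc(Nc2ncc(Cl)c(Nc3cccc(C(F)(F)F)c3)n2)c(OC)cc1N1CCN(C)CC1`: 260 nM in a functional assay on NCI-H1975 cells (Homo sapiens) for inhibition, read by CellTiter-Glo, with a stated time of 72 h; a higher number here means a weaker inhibitor of growth, a lower number a stronger inhibitor of growth.
Compound 2 `C=CC(=O)Nc1cc(Nc2ncc(Cl)c(NC3CC3)n2)c(OC)cc1N1CCN(C)CC1`: > 10000 nM.

Compound 2 stands at a limit of this assay, so only a bound and no number is known for it (the limit of > 10000 nM in this assay, at which 1 of the 2 values shown sits). Going by the values given here, the one measured step, an at least 38-fold higher number from compound 1 to compound 2 (1.58 log units; beyond the scatter), is large and beyond the scatter. Compound 3 `C=CC(=O)Nc1cc(Nc2ncc(Cl)c(N(C)c3cccc(C(F)(F)F)c3)n2)c(OC)cc1N1CCN(C)CC1` is compound 2 with methyl(3-(trifluoromethyl)phenyl)amino in place of cyclopropylamino on an aromatic carbon. This brings back the aryl group that compound 1 carries, with a methyl added on the nitrogen. Because compound 1 gives 260 nM, compound 3 is expected to give a much lower number, by about an at least 16-fold lower number from compound 2 to compound 3 (1.22 log units; beyond the scatter). The estimate for compound 3 in this assay is 600 nM, within 150 nM to 3000 nM.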

Compound 3, concentration for 50% growth inhibition: 1800 nM
For compound 3 the middle estimate is 3.0-fold (0.48 log units) below the measured one; the range from low to high includes it.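

Across the compounds shown, an aromatic ring on this amine, rather than cyclopropyl, still lowers the number in this assay when the nitrogen also carries a methyl (an at least 5.5-fold lower number from compound 2 to compound 3 (0.74 log units; beyond the scatter)). Compound 2 stands at a limit, not at a number: (the limit of > 10000 nM in this assay, at which 1 of the 3 values shown sits). At the same position, the methyl in place of the hydrogen on this nitrogen gives a weaker inhibitor of growth (a 6.9-fold higher number from compound 1 to compound 3 (0.84 log units; beyond the scatter)).

On these data alone, it remains open what an ethyl group on this nitrogen would give. As far as these compounds go, it is also open whether a cyclohexyl or an unsubstituted phenyl group would behave like the 3-(trifluoromethyl)phenyl group or like cyclopropyl.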